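The compounds below may be only part of what the source reports. "The series", "measured", "known", "first", "only" and "open" are said of these compounds alone.

Working notes on the series, all read in an ADME assay on Huh-7 cells (Homo sapiens) for cytotoxicity, with a stated time of 72 h; on this read-out higher numbers stand for lower toxicity in this test and lower numbers for higher toxicity in this test. Compound 1 (`CCS(=O)(=O)Nc1ccc2c(c1)S(=O)(=O)N=C(c1c(O)c(-c3cccs3)nn(CCC(C)C)c1=O)N2`) gives > 33000 nM, which is a limit and not a number. Compound 2 (`CC(C)CCn1nc(-c2ccccc2)c(O)c(C2=NS(=O)(=O)c3cc(NS(C)(=O)=O)ccc3N2)c1=O`) gives > 1000 nM, also a limit. Among the measured compounds shown here, compound 2 therefore has no exact value, and the two limits set no order between the compounds. For the measured compounds named here, no step between measured compounds is available to serve as a guide.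

Compound 3 (`CC(C)CCn1nc(CC2=CCCC2)c(O)c(C2=NS(=O)(=O)c3cc(NS(C)(=O)=O)ccc3N2)c1=O`) has not yet been measured. It differs from compound 2 as follows: (cyclopent-1-en-1-yl)methyl in place of phenyl on an aromatic carbon. In words, (cyclopent-1-en-1-yl)methyl stands in place of phenyl on an aromatic carbon, and the rest of the structure is unchanged.

In this assay, neither measured compound has reached a number, so compound 3 is expected to return a limit as well. Any number that does appear is expected to lie on the low-toxicity side of the limit of compound 2. The expected change is a step that the limit leaves unreadable from compound 2 to compound 3, a rough size. For compound 3 the estimated value is 10000 nM, with an expected range of 1500 nM to 40000 nM.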

Compound 3, half-maximal cytotoxic concentration: > 33000 nM
Compound 3: a limit, no number; the forecaster's own chance of this, stated with the estimate: 80%; middle value at least 3.3-fold (0.51 log units) from the limit.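

In this assay compound 3 gives > 33000 nM, a limit and not a number. Compound 2 gives > 1000 nM, also a limit. Among the compounds shown here, no step between compound 2 and compound 3 can be read from these two limits. The compounds shown leave open where any exact half-maximal cytotoxic concentration lies, and whether (cyclopent-1-en-1-yl)methyl in place of phenyl changes it.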